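From Chloro to Methoxy on the Benzyl Ring

A few compounds are considered here, and "the series" means these few. Any claim that something is new, unique, unknown or untested is made for them only; others in the source may bear on it.

Measured so far:
compound 1 `COc1nn(Cc2cccc([N+](=O)[O-])c2)c(=O)o1`: 7%
compound 2 `COc1nn(Cc2cccc(Cl)c2)c(=O)o1`: 37%

For the measured compounds named here, in an assay on COS-7 cells for inhibition of Fatty-acid amide hydrolase 1 (Homo sapiens), read by scintillation counting, with a stated time of 10 min, tested at 10 uM (a lower number here means less inhibition, a higher number more inhibition at the concentration tested (going by the name of the read-out)), compound 2 stands highest of the two numbers, the only measured step being a number 30 percentage points higher from compound 1 to compound 2 (beyond the scatter) for chloro in place of nitro on an aromatic carbon. Compound 3 `COc1cccc(Cn2nc(OC)oc2=O)c1` differs from compound 2 by methoxy in place of chloro on an aromatic carbon. Going by the values given here, no measured step concerns a chloro to methoxy exchange, so the expectation rests on compound 2 alone, with wide uncertainty and no clear direction. Compound 3 is therefore expected to give 25%, within 5% to 50%, a step of a number 12 percentage points lower from compound 2 to compound 3 (beyond the scatter) that may stay inside the scatter.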

Compound 3, a percentage reported as inhibition, at one concentration (the size of the read-out at that concentration, not a potency): "not active" (no number reported)
No number was reported for compound 3; no gap can be computed for the estimate.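

For the compounds shown here, compound 3 is reported only as "not active", without a number, so no step from compound 2 to compound 3 can be read, and no evidence bears on this result. As far as these compounds go, how far methoxy in place of chloro lowers inhibition remains open.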